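The compounds below may be only part of what the source reports. "The series", "measured", "known", "first", "only" and "open" are said of these compounds alone.

Working notes on the series. In a functional assay on HCT-116 cells (Homo sapiens) for cytotoxicity, read by MTT assay (on this read-out lower numbers stand for stronger inhibition and higher numbers for weaker inhibition), compound 1 `CCn1cc(-c2nc3ccc([N+](=O)[O-])cc3o2)c(=O)c2cc(F)c(N3CCNC(C)C3)c(F)c21` gives 1100 nM. Compound 2 `CCn1cc(C(=O)Nc2ccccc2N)c(=O)c2cc(F)c(N3CCNC(C)C3)c(F)c21`, the amide bearing the 2-aminophenyl group, gives 2700 nM in this assay, the second highest of the three numbers; its nearest neighbour is compound 3 `CCn1cc(C(=O)Nc2ccc(Cl)cn2)c(=O)c2cc(F)c(N3CCNC(C)C3)c(F)c21`, which gives 3300 nM, and its furthest is compound 1, whose number is lower by an amount beyond the scatter. For the measured compounds named here, the single step among the amides, a 1.2-fold higher number from compound 2 to compound 3 (0.09 log units; within the scatter), stayed within the scatter.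

Compound 4 `CCn1cc(C(=O)Nc2cc([N+](=O)[O-])ccc2F)c(=O)c2cc(F)c(N3CCNC(C)C3)c(F)c21` has not yet been measured in this assay. Its change from compound 2 is 2-fluoro-5-nitrophenyl in place of 2-aminophenyl on an amide-type nitrogen. The step from compound 2 to compound 3 bears on it most directly, as the same kind of aryl exchange on the amide-type nitrogen, and it was within the scatter. Going by the values given here, compound 1 also carries a nitro group, on a different attachment, and sits lower, but no single step links compound 1 to compound 2, so only the two values speak. The expected step of a 1.4-fold lower number from compound 2 to compound 4 (0.13 log units; within the scatter) is therefore small, leaning toward a lower number. Compound 4 is estimated at 2000 nM, with an expected range of 800 nM to 5000 nM.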

Compound 4, half-maximal inhibitory concentration: 2600 nM
The estimate for compound 4 lay 1.3-fold (0.11 log units) below the measured number; measured number inside the range.
By their numbers in this assay, from the lowest: compound 1; then compounds 4, 2 and 3 (each within the scatter of the next).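

In this assay, the exchange on the amide-type nitrogen now covers a third aryl group, and both new steps, a 1.0-fold lower number from compound 2 to compound 4 (0.02 log units; within the scatter) and a 1.3-fold lower number from compound 3 to compound 4 (0.10 log units; within the scatter), lie within the scatter. The entering 2-fluoro-5-nitrophenyl has more heavy atoms than 2-aminophenyl and no hydrogen-bond donor where 2-aminophenyl has one, yet compounds 2, 3 and 4 all stay within the scatter of each other, so this position shows no difference that can be read among these three aryl groups. No accompanying measurement offers an explanation for this result.

On these data alone, whether a non-aromatic group on the amide-type nitrogen, such as cyclohexyl or a longer alkyl chain, or an aryl group carrying a carboxylic acid would stay within the same scatter remains open. For the compounds shown here, the role of the amide link itself is also open, as no step connects compound 1 to the amides.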